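The source may report more compounds than this note shows. Statements on the series, on what has been measured and on what is new or still open speak of the compounds shown alone.

Measured so far in an assay on isolated protein for inhibition of Nitric oxide synthase, inducible (Homo sapiens), read by scintillation counting, with a stated time of 30 min, tested at 50 uM; a lower number here means less inhibition, a higher number more inhibition at the concentration tested (going by the name of the read-out):
compound 1 `CC1(C)SC(c2ccccc2N)=NN1C(=O)c1ccccc1` — 39.8%
compound 2 `CCCC(=O)N1N=C(c2cc(OC)ccc2N)SC1(C)C` — 91.1%
compound 3 `CCCCC(=O)N1N=C(c2cc(OC)ccc2N)SC1(C)C` — 101%

Compound 3 and compound 2 sit together at the upper end of these numbers, separated only within the scatter; compound 1 stands far apart from compound 3, beyond the scatter. Among the compounds with values here, the single one-point step measured, a number 9.9 percentage points higher from compound 2 to compound 3 (within the scatter), extended the acyl chain and left the read-out essentially where it was.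

Compound 4 `COc1ccc(N)c(C2=NN(C(=O)C3CCCC3)C(C)(C)S2)c1` differs from compound 3 by cyclopentyl in place of butyl on a carbonyl carbon. Within the data shown here, the change is again confined to the group on the carbonyl carbon, and the only measured step that bears on it is a number 9.9 percentage points higher from compound 2 to compound 3 (within the scatter), which stayed within the scatter. Among the measured compounds shown here, no measured pair shows what a five-membered ring in place of an open chain does at this position, so the expectation rests on the acyl changes seen so far having moved the read-out little. The number for compound 3 already sits at the upper end of these read-outs, which leaves little room for a rise. Compound 4 is therefore expected to give 96%, with a range of 80% to 106%. The step of a number 5 percentage points lower from compound 3 to compound 4 (within the scatter) is expected to remain within the scatter.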

Compound 4, a percentage reported as inhibition, at one concentration (the size of the read-out at that concentration, not a potency): 65%
For compound 4 the middle estimate is 31 percentage points above the measured one; measured number outside the range, below it.
By their numbers in this assay, from the lowest: compound 1; then compound 4; then compounds 2 and 3 (each within the scatter of the next).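

On the carbonyl carbon, cyclopentyl separates from both open chains in this assay (a number 36 percentage points lower from compound 3 to compound 4 (beyond the scatter)) (a number 26.1 percentage points lower from compound 2 to compound 4 (beyond the scatter)). This position therefore does respond to the group it carries, which the chain extension alone did not show (a number 9.9 percentage points higher from compound 2 to compound 3 (within the scatter)), a step that stayed within the scatter. Nothing at hand accounts for the drop on going from an open chain to the five-membered ring.

Still open, from the compounds shown here alone, is whether the loss belongs to cyclopentyl alone: an isopropyl or a cyclohexyl on the same carbonyl carbon could fall with compound 4 or stay with compound 2 and compound 3. Also open, going by these compounds, is whether a longer chain, such as hexyl, would hold the read-out seen for butyl.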